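Inverting one ring stereocentre in a dimeric sodium/hydrogen exchanger inhibitor

The compounds below may be only part of what the source reports. "The series", "measured", "known", "first", "only" and "open" are said of these compounds alone.

The series starts from the monomer compound 1 `CN1Cc2c(Cl)cc(Cl)cc2C(c2cccc(S(=O)(=O)NCC(=O)O)c2)C1`, which in an assay on cells (Kidney epithelial cell, kidney) for inhibition of sodium/hydrogen exchanger 3 (Homo sapiens), read by fluorescence, in the presence of a further agent that is not named here (on this read-out lower numbers stand for stronger inhibition and higher numbers for weaker inhibition), gives 100 nM. Compound 2 `CN1Cc2c(Cl)cc(Cl)cc2C(c2cccc(S(=O)(=O)NCCOCCOCCOCCNC(=O)C(O)C(O)NCCOCCOCCOCCNS(=O)(=O)c3cccc(C4CN(C)Cc5c(Cl)cc(Cl)cc54)c3)c2)C1`, a dimer drawn without configuration at its two ring stereocentres, gives 79.4 nM. Compound 3 `CN1Cc2c(Cl)cc(Cl)cc2[C@H](c2cccc(S(=O)(=O)NCCOCCOCCOCCNC(=O)C(O)C(O)NCCOCCOCCOCCNS(=O)(=O)c3cccc([C@@H]4CN(C)Cc5c(Cl)cc(Cl)cc54)c3)c2)C1`, with both ring stereocentres drawn S, gives 1.26 nM, the lowest number of the three: compound 2 sits a good deal higher and compound 1 higher still. The step of a 63-fold lower number from compound 2 to compound 3 (1.80 log units; beyond the scatter) is large, and the only thing known about it is the fact that one of compounds 2 and 3 is drawn with a defined configuration and the other without, at the place where they differ.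

Compound 4 `CN1Cc2c(Cl)cc(Cl)cc2[C@@H](c2cccc(S(=O)(=O)NCCOCCOCCOCCNC(O)C(O)C(=O)NCCOCCOCCOCCNS(=O)(=O)c3cccc([C@@H]4CN(C)Cc5c(Cl)cc(Cl)cc54)c3)c2)C1` carries the change (the two compounds have the same atoms and bonds; at least one stereo element is drawn with a configuration in one of them and without one in the other: 1 of 4 stereo elements differ; a stereocentre at a saturated ring carbon is drawn S in compound 3 and R in compound 4); in words, the two compounds have the same atoms and bonds, and one of the four stereo elements differs, a stereocentre at a saturated ring carbon drawn S in compound 3 and R in compound 4. Among the measured compounds shown here, the single step that bears on this, from compound 2 to compound 3, shows that fixing the configurations moves the number far, so the configuration at these ring carbons matters. Because compound 2 gives 79.4 nM while compound 3 gives 1.26 nM, compound 4 is expected to land between them, with a step of a 16-fold higher number from compound 3 to compound 4 (1.20 log units; beyond the scatter) that is beyond the scatter. Compound 4 is therefore estimated at 20 nM, within a range of 3 nM to 160 nM.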

Compound 4, half-maximal inhibitory concentration: 200 nM
Estimate against measurement, compound 4: 10-fold (1.00 log units) below; measured number above the stated range.
By their numbers in this assay, from the lowest: compound 3; then compounds 2, 1 and 4 (each within the scatter of the next, the first and the last beyond it).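

Changing one stereocentre at a saturated ring carbon, drawn S in compound 3 and R in compound 4, is enough on its own to produce a large move in this assay, namely a 160-fold higher number from compound 3 to compound 4 (2.20 log units; beyond the scatter). So the two ring stereocentres cannot be treated as interchangeable: having one of them S does not preserve the low number of compound 3, and compound 4, with one centre drawn R and one drawn S, lies on the far side of the undefined dimer, with a 2.5-fold higher number from compound 2 to compound 4 (0.40 log units; beyond the scatter). The configuration at this one carbon is the only difference known for the large step, and no reason for its size can be taken further than this: the fact that one of compounds 3 and 4 is drawn with a defined configuration and the other without, at the place where they differ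

What the compounds shown leave open is how a dimer with both ring stereocentres drawn R would read in this assay, and whether the configuration matters as much in the monomer compound 1, with its carboxylic acid. They also leave open whether the same preference for S holds with a longer chain joining the two halves, or with an amine in that chain.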